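Replacing the aryl sulfone group of compound 3

This account rests on a few compounds, and the source may have more. Where it says the series, first, only, none or still open, it means among the compounds named here.

Within the series compound 3 `CCN1CCC(n2cc(S(=O)(=O)c3cccc(F)c3)c3cccnc32)C1` stands at the high end: in an assay on HeLa cells for displacement of a labelled ligand from 5-hydroxytryptamine receptor 6 (Homo sapiens) (a lower number here means a stronger inhibitor, a higher number a weaker inhibitor), compound 3 gives 8.3 nM, while compound 1 `O=S(=O)(c1cccc(F)c1)c1cn(C2CCNC2)c2ncccc12` gives 2.7 nM and compound 2 `O=S(=O)(c1cccc(Br)c1)c1cn(C2CCNC2)c2ncccc12` gives 1.3 nM. The two steps that connect the measured compounds were both modest: a 2.1-fold lower number from compound 1 to compound 2 (0.32 log units; beyond the scatter), and a 3.1-fold higher number from compound 1 to compound 3 (0.49 log units; beyond the scatter). Compound 4 `CCN1CCC(n2cc(S(=O)(=O)C3=C(Cl)NC4SC=CN34)c3cccnc32)C1` keeps the ethyl-substituted amine of compound 3 and changes the group on the sulfonyl sulfur: a group of 9 heavy atoms (5 carbon, 2 nitrogen, 1 sulfur, 1 chlorine; 2 five-membered non-aromatic rings with 2 hetero atoms each) in place of a group of 7 heavy atoms (6 carbon, 1 fluorine; one six-membered aromatic ring of carbon only), on a sulfonyl sulfur. Among the measured compounds shown here, only the step from compound 1 to compound 2 touches that part of the molecule, and it merely swapped one halogen for another on an aromatic carbon with a modest effect; no measured step removes the aromatic ring altogether. For the measured compounds named here, with no precedent for so large a replacement, a weakening beyond the scatter is expected, with wide uncertainty. Compound 4 is estimated at 40 nM in this assay, within 8 nM to 200 nM, an expected step of a 4.8-fold higher number from compound 3 to compound 4 (0.68 log units; beyond the scatter).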

Compound 4, inhibition constant: 1.4 nM
For compound 4 the middle estimate is 29-fold (1.46 log units) above the measured one, outside the stated range (below it).
By their numbers in this assay, from the lowest: compounds 2, 4 and 1 (each within the scatter of the next, the first and the last beyond it); then compound 3.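

Notes on the sulfonyl sulfur position: in this assay, the 3-fluorophenyl group is not required, since its replacement gives a 5.9-fold lower number from compound 3 to compound 4 (0.77 log units; beyond the scatter) and thus a gain rather than a loss. Up to now this position had been varied only by exchanging one halogen for another on the aromatic ring, whereas this change shows that a group with 2 five-membered non-aromatic rings with 2 hetero atoms each, and no aromatic ring of carbon only, is accepted on the sulfonyl sulfur when the ring amine carries ethyl. Nothing available on these compounds accounts for the gain.

Open, as far as these compounds go, is whether the new group gives a similar gain with hydrogen in place of ethyl on the ring amine nitrogen, and whether its chlorine contributes to the result. Also open, from the compounds shown here alone, is how a pyridine ring or a simple methyl group would behave on the sulfonyl sulfur.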